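Benzoxaborole amides: from isopropyl anilide to trifluoromethyl biaryl

This account rests on a few compounds, and the source may have more. Where it says the series, first, only, none or still open, it means among the compounds named here.

Measured compounds:
- compound 1, `CC(C)(C)NC(=O)CCc1cccc2c1B(O)OC2`: > 100000 nM
- compound 2, `CC(C)c1cccc(NC(=O)CCc2cccc3c2B(O)OC3)c1`: 510 nM
- compound 3, `O=C(CCc1cccc2c1B(O)OC2)Nc1cccc2ccccc12`: 170 nM

The three measured amides share one core and differ only in the group on the amide nitrogen. In a functional assay on SK-OV-3 cells (Homo sapiens) for antiproliferative activity, read by MTT assay, with a stated time of 72 h (on this read-out lower numbers stand for stronger inhibition and higher numbers for weaker inhibition), compound 1 gives > 100000 nM, which is a limit of the assay rather than a number. Compound 2, the anilide bearing an isopropyl group, gives 510 nM in this assay. Compound 3, the naphthyl anilide, gives 170 nM in this assay. Of the two numbers shown, compound 2 stands highest; compound 3 sits a step below it that lies beyond the usual scatter (the limit of > 100000 nM in this assay, at which 1 of the 3 values shown sits, is the only other entry, and it is a limit).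

Compound 4, `O=C(CCc1cccc2c1B(O)OC2)Nc1cccc(-c2cccc(C(F)(F)F)c2)c1`, has not yet been measured. It differs from compound 2 by 3-(trifluoromethyl)phenyl in place of isopropyl on an aromatic carbon. Going by the values given here, no step between measured compounds matches this change, so the expectation rests on what the two numbers show: the anilide carrying a larger aromatic group, compound 3, gives the lower number. Compound 4 is therefore expected to give a lower number than compound 2, by a step of a 2.6-fold lower number from compound 2 to compound 4 (0.41 log units; beyond the scatter), modest in size but beyond the scatter. The estimate for compound 4 in this assay is 200 nM, within 60 nM to 700 nM.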

Compound 4, half-maximal inhibitory concentration: 390 nM
Beside the measured number, compound 4's estimate is 2.0-fold (0.29 log units) below it; measured number inside the range.
By their numbers in this assay, from the lowest: compound 3; then compounds 4 and 2 (each within the scatter of the next). At a limit, above all of these: compound 1.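

The position on an aromatic carbon of the anilide ring, meta to a large group, now has two substituents that can be compared directly, and they differ greatly in size. In this assay, going by these compounds alone, replacing isopropyl, with 3 heavy atoms and no ring, by 3-(trifluoromethyl)phenyl, with 10 heavy atoms and one six-membered aromatic ring, gives a 1.3-fold lower number from compound 2 to compound 4 (0.12 log units; within the scatter) and so leaves the two compounds indistinguishable on this read-out, which the earlier compounds could not show because none of them formed a pair differing at this position alone. Nothing measured here bears on why so large an exchange leaves the number within the scatter.

The compounds shown leave open how this position responds to a group of another kind, such as an amine or a carboxylic acid, and whether a plain phenyl group would read the same as 3-(trifluoromethyl)phenyl. They also leave open whether a longer chain between the amide carbonyl and the shared core would change the number for either anilide.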